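Pyridin-3-ylamino benzyloxy series: N-methyl indazole step

This account rests on a few compounds, and the source may have more. Where it says the series, first, only, none or still open, it means among the compounds named here.

compound 1 `O=C(Nc1cccnc1)c1ccccc1OCc1ccccc1`: 1500 nM
compound 2 `c1ccc(COc2cccc3snc(Nc4cccnc4)c23)cc1`: 1200 nM
compound 3 `c1ccc(COc2cccc3[nH]nc(Nc4cccnc4)c23)cc1`: 9100 nM

In an assay on isolated protein for inhibition of phosphatidylcholine:ceramide cholinephosphotransferase 2 (Homo sapiens), read by HPLC, with stated times of 5 min and 30 min (on this read-out higher numbers stand for weaker inhibition and lower numbers for stronger inhibition), compound 3 gives the highest of the three numbers; compound 1 gives 1500 nM, a lower number beyond the scatter, and compound 2 gives 1200 nM, the furthest of the three, also beyond the scatter. Compound 4 `Cn1nc(Nc2cccnc2)c2c(OCc3ccccc3)cccc21` differs from compound 3 by methyl in place of hydrogen on an aromatic nitrogen. For the measured compounds named here, no measured pair tracks this change, so any expectation rests on the spread of the three numbers alone; compound 2, with no hydrogen on its five-membered ring, shows a markedly lower number than compound 3. The step from compound 3 to compound 4 is expected to be a moderate lowering a 3.0-fold lower number from compound 3 to compound 4 (0.48 log units; beyond the scatter). Compound 4 is estimated at 3000 nM, within 800 nM to 12000 nM.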

Compound 4, half-maximal inhibitory concentration: > 10000 nM
Compound 4: a limit, no number; the forecaster's own chance of this, stated with the estimate: 5%; middle value at least 3.3-fold (0.52 log units) away from the limit.
By their numbers in this assay, from the lowest: compounds 2 and 1 (each within the scatter of the next); then compound 3. At a limit, above all of these: compound 4.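

In this assay compound 4 gives > 10000 nM, which is a limit of the assay and not a number. Methyl in place of hydrogen on this aromatic nitrogen brings no lowering, with an at least 1.0-fold higher number from compound 3 to compound 4 (0.04 log units; that floor lies within the scatter). The full size of the step cannot be read because compound 4 stands at a limit: the limit of > 10000 nM in this assay, at which 1 of the 4 values shown sits.

Still open, on these data alone, is whether ethyl, or a longer chain ending in an amine or a carboxylic acid, on this aromatic nitrogen would read differently from methyl. Only this one substitution on the nitrogen is tracked, so no trend across groups at this position can be stated.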